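Carbamoyl to sulfamoylmethyl on the chloro compound

This account rests on a few compounds, and the source may have more. Where it says the series, first, only, none or still open, it means among the compounds named here.

Compound 1 `N#Cc1c[nH]c2c(NS(=O)(=O)c3ccc(C(N)=O)cc3)cccc12` gives 2.5 ug/mL
Compound 2 `NC(=O)c1ccc(S(=O)(=O)Nc2cccc3c(Cl)c[nH]c23)cc1` gives 0.87 ug/mL

In a functional assay on P388 cells (Mus musculus) for antiproliferative activity (a lower number here means a stronger inhibitor, a higher number a weaker inhibitor), compound 2 gives 0.87 ug/mL and stands lowest of the two measured, with compound 1 at 2.5 ug/mL above it. Compound 3 `NS(=O)(=O)Cc1ccc(S(=O)(=O)Nc2cccc3c(Cl)c[nH]c23)cc1` carries sulfamoylmethyl in place of carbamoyl on an aromatic carbon and awaits measurement. Going by the values given here, the only measured step (a 2.9-fold lower number from compound 1 to compound 2 (0.46 log units; beyond the scatter)) is modest and concerns another group, so no measured step bears directly on this change. The expected move (a 1.1-fold higher number from compound 2 to compound 3 (0.06 log units; within the scatter)) therefore stays within the scatter, with no direction favoured. Compound 3 is estimated at 1 ug/mL with an expected range from 0.3 ug/mL to 3.2 ug/mL in this measurement.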

Compound 3, half-maximal inhibitory concentration: 0.15 ug/mL
Compound 3: middle estimate off by 6.7-fold (0.82 log units), on the high side, outside the stated range (below it).
By their numbers in this assay, from the lowest: compound 3; then compound 2; then compound 1.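

In this assay, sulfamoylmethyl in place of carbamoyl on the aromatic carbon para to a large group gives a 5.8-fold lower number from compound 2 to compound 3 (0.76 log units; beyond the scatter). Going by these compounds alone, this is the first measured change at this position, and it shows that the number here responds to the group carried there, with the chloro group held constant. Nothing available accounts for this move. The compounds shown leave open how a sulfamoyl group without the methylene, a carboxylic acid or an amine would read at this position. They also leave open whether the same exchange would hold with the cyano group of compound 1.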